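The source may hold more compounds than are shown below. What is called first, only, known or untested is meant among the compounds shown, and "the series" means these compounds.

Compound 1 `COc1ccc2occ(CSC(=S)N(C(C)C)C(C)C)c(=O)c2c1` was examined in a functional assay on MCF7 cells (Homo sapiens) for antiproliferative activity, read by MTT assay, with a stated time of 72 h; on this read-out higher numbers stand for weaker inhibition and lower numbers for stronger inhibition. In this assay compound 1 gives > 40000 nM, which is a limit of the assay rather than a number. Compound 1 therefore sits at the limit of > 40000 nM in this assay, at which 1 of the 3 values shown sits, one edge of the three measurements, and nothing finer can be said of its position. Compound 2 `COc1ccc2occ(CSC(=S)N3CCOCC3)c(=O)c2c1` carries a morpholin-4-yl group where compound 1 carries a diisopropylamino group on the thiocarbonyl carbon, and in this assay compound 2 gives 11800 nM. That single change produced an at least 3.3-fold lower number from compound 1 to compound 2 (0.53 log units; beyond the scatter). Compound 3 `O=c1c(CSC(=S)N2CCN(C(c3ccc(F)cc3)c3ccc(F)cc3)CC2)coc2ccccc12` differs from compound 1 in more than one place. In this assay compound 3 gives > 30000 nM, again a limit of the assay. Compound 4 `CC(C)N(C(=S)SCc1coc2ccccc2c1=O)C(C)C` differs from compound 1 only by hydrogen in place of methoxy on an aromatic carbon. Going by the values given here, no measured step covers this change; the one measured step concerns the amine, not the methoxy group, so it gives no guidance here. Since the starting point is known only as a limit, compound 4 is expected to show a step that the limit leaves unreadable from compound 1 to compound 4 in this assay. Compound 4 is accordingly estimated at 50000 nM, within 15000 nM to 150000 nM.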

Compound 4, half-maximal inhibitory concentration: > 30000 nM
Compound 4: only a limit was reported (the forecaster's own chance of this, stated with the estimate: 75%); the middle value is on the limit's open side.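

Going by these compounds alone, compound 1 and compound 4 are both known only as limits of this assay, so no step between them can be read. The compounds shown leave open whether hydrogen in place of methoxy on an aromatic carbon changes the result at all.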